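Swapping a methoxy for chloro in a cytotoxicity series

This account rests on a few compounds, and the source may have more. Where it says the series, first, only, none or still open, it means among the compounds named here.

Compound 1 `COc1ccc([C@H]2CC(C)(O)[C@@H]3CC[C@@H](C)C[C@H]3O2)cc1` is the starting point. For the measured compounds named here, in an ADME assay on MDCK cells (Canis lupus familiaris) for cytotoxicity, read by MTT assay, with a stated time of 48 h (on this read-out lower numbers stand for higher toxicity in this test and higher numbers for lower toxicity in this test), compound 1 gives 689000 nM, the only outright number among the three measured compounds. Compound 2 `COc1ccc([C@H]2CC(C)(O)[C@@H]3CC[C@@H](C)C[C@H]3O2)c(OC)c1` carries an additional methoxy on an aromatic carbon. In this assay compound 2 reaches only a limit of the assay, > 937000 nM. Compound 3 `COc1ccc([C@H]2CC(C)(O)[C@@H]3CC[C@@H](C)C[C@H]3O2)cc1OC` adds a methoxy on another aromatic carbon. In this assay compound 3 likewise stops at a limit, > 937000 nM. Both of these later compounds sit at the limit of > 937000 nM in this assay, at which 2 of the 3 values shown sit. The step of an at least 1.3-fold higher number from compound 1 to compound 2 (0.13 log units; that floor lies within the scatter) and the step of an at least 1.3-fold higher number from compound 1 to compound 3 (0.13 log units; that floor lies within the scatter) thus stay within the scatter, so compound 1 is not separated from its two neighbours by anything the numbers can resolve.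

Compound 4 `C[C@@H]1CC[C@@H]2[C@@H](C1)O[C@@H](c1ccc(Cl)cc1)CC2(C)O` differs from compound 1 by chloro in place of methoxy on an aromatic carbon. Going by the values given here, no measured step involves this exchange; the two steps that exist each add a methoxy on an aromatic carbon and change nothing beyond the scatter. Nothing among these three compounds moves the read-out in this assay, so no step beyond the scatter is expected for compound 4 either, and the value may again fall at a limit. The estimate for compound 4 is 700000 nM, with a range from 300000 nM to 1400000 nM. The expected step of a 1.0-fold higher number from compound 1 to compound 4 (0.01 log units; within the scatter) is accordingly small.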

Compound 4, half-maximal cytotoxic concentration: 62000 nM
The estimate for compound 4 lay 11-fold (1.05 log units) above the measured number; the measured number lies below the stated range.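

For the compounds shown here, the aromatic carbon para to a large group turns out to matter in this assay: chloro in place of methoxy there gives an 11-fold lower number from compound 1 to compound 4 (1.05 log units; beyond the scatter) and is the first change to clear the scatter. Compound 2 and compound 3 both keep the methoxy at this place and add a second one elsewhere on the aromatic ring, so only compound 4 shows what happens when that methoxy is exchanged, and here a lower number stands for higher toxicity in this test. Nothing measured here explains why this exchange has so large an effect.

Going by these compounds, a single exchange cannot separate the departure of the methoxy from the arrival of the chloro, so it remains open whether a plain hydrogen, a fluoro or a methyl at the same place would lower the number as far. Also open, on these data alone, is whether an amine or a carboxylic acid there would shift the number in either direction, and whether chloro on another aromatic carbon of the shared core would act in the same way.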